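Compound 4: An Oxetane Exchange and Its Expected Half-Life

The source may report more compounds than this note shows. Statements on the series, on what has been measured and on what is new or still open speak of the compounds shown alone.

Measured so far in an ADME assay on microsomes from liver (Rattus norvegicus, strain Sprague-Dawley) for metabolic stability, read by HPLC, using NADPH, with stated times of 5 min and 60 min, tested at 10 uM; on this read-out lower numbers stand for a shorter-lived compound and higher numbers for a longer-lived compound:
Compound 1 `CS(=O)(=O)Nc1ccc(CNC(=O)c2ccc(C34CC(C3)C4)cc2)c(Cl)c1` gives 1.35 h.
Compound 2 `COc1ccc(C(=O)NCc2ccc(NS(C)(=O)=O)cc2Cl)cc1` gives 4.5 h.
Compound 3 `COC(C)(C)c1ccc(C(=O)NCc2ccc(NS(C)(=O)=O)cc2Cl)cc1` gives 0.917 h.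

Among these three, compound 1 stands second highest. Its nearest neighbour is compound 3, a step within the scatter: a 1.5-fold lower number from compound 1 to compound 3 (0.17 log units; within the scatter). Its furthest is compound 2, a step beyond the scatter: a 3.3-fold higher number from compound 1 to compound 2 (0.52 log units; beyond the scatter). The new compound 4 `CS(=O)(=O)Nc1ccc(CNC(=O)c2ccc(C3(O)COC3)cc2)c(Cl)c1` differs from compound 1 in one place: a group of 5 heavy atoms (3 carbon, 2 oxygen; one four-membered non-aromatic ring with 1 hetero atom) in place of a group of 5 heavy atoms (5 carbon; 2 four-membered non-aromatic rings of carbon only), on an aromatic carbon.

Both measured steps from compound 1 bear on this exchange. Each of them also replaces the same group on that aromatic carbon with a group carrying oxygen. One rose beyond the scatter, the other stayed within it, and neither entering group is the 3-hydroxyoxetan-3-yl itself. A modest rise, or no step beyond the scatter, is therefore expected in this assay. Compound 4 is expected to give 2.2 h, within a range from 1 h to 5 h, which means an expected step of a 1.6-fold higher number from compound 1 to compound 4 (0.21 log units; within the scatter).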

Compound 4, half-life: 4.23 h
For compound 4 the middle estimate is 1.9-fold (0.28 log units) below the measured one; the range from low to high includes it.
By their numbers in this assay, from the lowest: compounds 3 and 1 (each within the scatter of the next); then compounds 4 and 2 (each within the scatter of the next).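

In this assay, putting 3-hydroxyoxetan-3-yl on this aromatic carbon gives a 3.1-fold higher number from compound 1 to compound 4 (0.50 log units; beyond the scatter), so a group of the same heavy-atom count as the one it replaces can go with a longer half-life at this position. Carrying oxygen in the group does not settle the number on its own, as 1-methoxy-1-methylethyl also carries oxygen and the exchange shows a 4.6-fold higher number from compound 3 to compound 4 (0.66 log units; beyond the scatter). Against methoxy, a group with fewer heavy atoms, the exchange gives a 1.1-fold lower number from compound 2 to compound 4 (0.03 log units; within the scatter), which leaves these two groups level here.

From the compounds shown here alone, whether the hydroxyl or the oxetane ring matters more stays open, as does how a group such as 3-aminooxetan-3-yl or a carboxylic acid would fare at this place. No measurement shown here explains why these groups differ.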